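The source may report more compounds than this note shows. Statements on the series, on what has been measured and on what is new or still open speak of the compounds shown alone.

Within the data shown here, compound 2 `CC(C)(C)OC(=O)CCC[N+]1(C)CCc2c(sc(NC(=O)Nc3ccc(Cl)cc3)c2C(N)=O)C1` gives 250 nM in a functional assay (strain AB) with Danio rerio as the target, read by microscopy, with a stated time of 1 h (on this read-out lower numbers stand for an effect already at smaller amounts and higher numbers for an effect only at larger amounts of compound), and this is the only true number available on that read-out. In this assay compound 1 `CCN1CCc2c(sc(NC(=O)Nc3ccccc3)c2C(N)=O)C1` reaches only a limit, > 25000 nM. Compound 3 `C[N+]1(CC2CCCCC2)CCc2c(sc(NC(=O)Nc3ccc(Cl)cc3)c2C(N)=O)C1` differs from compound 2 as follows: cyclohexyl in place of 2-(tert-butoxycarbonyl)ethyl on a saturated chain carbon bound to an amine nitrogen in a ring. In short, cyclohexyl stands in place of 2-(tert-butoxycarbonyl)ethyl on a saturated chain carbon bound to an amine nitrogen in a ring. Among the measured compounds shown here, no measured step shows what such a change does, so a modest rise in the number is expected in this assay, with the estimated step of a 2.0-fold higher number from compound 2 to compound 3 (0.30 log units; within the scatter). For compound 3 the expected value is 500 nM, with an estimated range of 100 nM to 2500 nM.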

Compound 3, half-maximal effective concentration: 100 nM
Estimate against measurement, compound 3: 5.0-fold (0.70 log units) above, and the stated range covers the measured number.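

In this assay, among these compounds, cyclohexyl in place of 2-(tert-butoxycarbonyl)ethyl gives a 2.5-fold lower number from compound 2 to compound 3 (0.40 log units; beyond the scatter) and is the first measured step on this saturated chain carbon bound to an amine nitrogen in a ring. The effect therefore does not depend on the tert-butoxycarbonyl group, and a carbon-only ring at this place gives a lower number beyond the scatter. Nothing measured here accounts for this step.

From the compounds shown here alone, whether a carboxylic acid, an amine or a longer chain at this place would lower the number further remains open. A single step also leaves open whether this change would act alike with other groups on the shared core.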